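Amino for trifluoromethoxy: expected cytotoxicity of compound 3

The source may hold more compounds than are shown below. What is called first, only, known or untested is meant among the compounds shown, and "the series" means these compounds.

- compound 1 (`Cc1cc(NC(=O)Nc2ccccc2N)c2ccccc2n1`): > 25000 nM (a limit)
- compound 2 (`Cc1cc(NC(=O)Nc2ccc(OC(F)(F)F)cc2)c2ccccc2n1`): 25000 nM (a number)

Among the measured compounds shown here, in an ADME assay on BJ cells (Homo sapiens) for cytotoxicity, with a stated time of 72 h (on this read-out lower numbers stand for an effect already at smaller amounts and higher numbers for an effect only at larger amounts of compound), compound 2 gives 25000 nM as the only actual number so far. Compound 1 gives > 25000 nM as a limit and not a number. Compound 1 carries an amino group on its aromatic ring, and the next compound carries one too.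

Compound 3 (`Cc1cc(NC(=O)Nc2ccc(N)cc2)c2ccccc2n1`) has amino in place of trifluoromethoxy on an aromatic carbon, para to a large group (amino in place of trifluoromethoxy on an aromatic carbon). For the measured compounds named here, no measured step in this small set covers that exchange, so the expectation is indirect and carries real uncertainty. It rests on compound 2 at 25000 nM and on the amino group shared with compound 1.

In this assay no step beyond the scatter is expected, in either direction. The estimated step of no change at the digits printed from compound 2 to compound 3 (within the scatter) is expected to stay within the scatter. For compound 3 the estimate is 25000 nM with an expected range of 10000 nM to 50000 nM and a report as a limit rather than a number is the likelier outcome.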

Compound 3, half-maximal effective concentration: > 25000 nM
Compound 3: only a limit was reported (the forecaster's own chance of this, stated with the estimate: 70%); the middle value lies on the limit itself.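

In this assay compound 3 gives > 25000 nM as a limit and not a number. Amino in place of trifluoromethoxy on an aromatic carbon, para to a large group, gives a number no lower from compound 2 to compound 3 (the limit leaves the size open), the first sign at this position that the exchange does not bring the value down, something the earlier compounds alone could not show. The step between the two compounds that carry amino groups cannot be read, and the result adds to a set in which most values sit at the same limit: the limit of > 25000 nM in this assay, at which 2 of the 3 values shown sit.

Going by these compounds, what stays open is the size of the exchange itself, as well as whether any group on this aromatic carbon gives a value that can be read clearly below the limit. A carboxylic acid, a methoxy group or a longer chain in the same place would test that, and the compounds shown say nothing on how any of them would read out in this assay on this shared core.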